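This account rests on a few compounds, and the source may have more. Where it says the series, first, only, none or still open, it means among the compounds named here.

Of the compounds shown here, three of the shared core have been measured in a functional assay on BHK cells for positive allosteric modulation of metabotropic glutamate receptor 5 (Homo sapiens), read by FLIPR and calcium flux; on this read-out higher numbers stand for an effect only at larger amounts of compound and lower numbers for an effect already at smaller amounts. Compound 1 `O=C(NCc1ccco1)c1ccc(C#Cc2ccccc2)nc1` gives 180 nM, compound 2 `O=C(NCc1ccsc1)c1ccc(C#Cc2ccccc2)nc1` gives 140 nM, and compound 3 `O=C(c1ccc(C#Cc2ccccc2)nc1)N1CCCCC1` gives 280 nM. Compound 3 carries the highest of the three numbers, yet its distance to the others is small: the change a 1.6-fold higher number from compound 1 to compound 3 (0.19 log units; within the scatter) and the change a 2.0-fold higher number from compound 2 to compound 3 (0.30 log units; within the scatter) both stay inside the usual scatter, as does a 1.3-fold lower number from compound 1 to compound 2 (0.11 log units; within the scatter) between the two open-chain amides. On the numbers shown, then, the three compounds cannot be separated.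

Compound 4 `CC1CCN(C(=O)c2ccc(C#Cc3ccccc3)nc2)CC1` is the next step from compound 3. The difference is methyl in place of hydrogen on a saturated ring carbon, or in words, methyl in place of hydrogen on a saturated ring carbon. Within the data shown here, none of the measured steps touches this position: the steps seen so far exchange the whole amine part, not a substituent on the piperidine ring. Among the measured compounds shown here, the only guidance is that every change recorded so far in this assay fell within the scatter, which gives no reason to expect a large move here either. Compound 4 is therefore expected to give about 250 nM in this assay, with a likely range from 90 nM to 700 nM, an expected step of a 1.1-fold lower number from compound 3 to compound 4 (0.05 log units; within the scatter) that is not beyond the scatter.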

Compound 4, half-maximal effective concentration: 130 nM
Compound 4: middle estimate off by 1.9-fold (0.28 log units), on the high side; the range from low to high includes it.
By their numbers in this assay, from the lowest: compounds 4, 2, 1 and 3 (each within the scatter of the next, the first and the last beyond it).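

In this assay, methyl in place of hydrogen on a saturated ring carbon, three ring bonds from the ring nitrogen, gives the first single-place step among these compounds that lies beyond the scatter (a 2.2-fold lower number from compound 3 to compound 4 (0.33 log units; beyond the scatter)), though the step is modest, and the earlier steps, which exchanged the whole amine part, had not touched this position. The added methyl separates compound 4 from compound 3 but not from the open-chain amides, since both of those steps remain within the scatter (a 1.1-fold lower number from compound 2 to compound 4 (0.03 log units; within the scatter)) and (a 1.4-fold lower number from compound 1 to compound 4 (0.14 log units; within the scatter)). Nothing available here accounts for the change brought by this methyl.

What the compounds shown leave open is whether this step belongs to methyl alone or would also appear with an ethyl, a hydroxyl or a fluorine on the same ring carbon. They also leave open whether a methyl on another carbon of the piperidine ring, or a morpholine in place of the piperidine, would give a number like that of compound 4 (130 nM) or one like that of compound 3 (280 nM).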